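The source may hold more compounds than are shown below. What is called first, only, known or untested is meant among the compounds shown, and "the series" means these compounds.

Measured in a functional assay on A549 cells (Homo sapiens) for inhibition, read by MTT assay, with a stated time of 48 h; on this read-out higher numbers stand for weaker inhibition and lower numbers for stronger inhibition:

- Compound 1 `COc1ccc(N(C)c2nc(C)nc3ccccc23)cc1C(=O)NCC[Se]C#N`: 187 nM
- Compound 2 `COc1ccc(N(C)c2nc(C)nc3ccccc23)cc1OCC[Se]C#N`: 13 nM

Compound 2 holds the lower of these two numbers. Compound 3 `COc1ccc(N(C)c2nc(C)nc3ccccc23)cc1OCCCCC[Se]C#N` has not yet been measured. Relative to compound 2, it carries a group of 6 heavy atoms (4 carbon, 1 nitrogen, 1 selenium; no ring) in place of a group of 3 heavy atoms (1 carbon, 1 nitrogen, 1 selenium; no ring), on a saturated chain carbon, two bonds along the chain from an oxygen on an aromatic ring. Within the data shown here, only one measured step bears on this change, and only indirectly. That step is a 14-fold lower number from compound 1 to compound 2 (1.16 log units; beyond the scatter), a large one beyond the scatter, made by exchanging a group on an aromatic carbon. It shows that numbers in this assay can move strongly when this group changes. Among the measured compounds shown here, no measured pair varies the chain length alone, so the data do not fix a direction. With compound 2 at 13 nM, a moderate move towards a higher number is expected. The expected change is a 2.3-fold higher number from compound 2 to compound 3 (0.36 log units; beyond the scatter). Compound 3 is estimated at 30 nM, with an expected range from 8 nM to 120 nM.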

Compound 3, half-maximal inhibitory concentration: 2440 nM
Beside the measured number, compound 3's estimate is 81-fold (1.91 log units) below it; the whole stated range lies below it.
By their numbers in this assay, from the lowest: compound 2; then compound 1; then compound 3.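

Within this assay, the longer chain ending in selenium and nitrile gives the first measured change at this place, on a saturated chain carbon, two bonds along the chain from an oxygen on an aromatic ring (a 190-fold higher number from compound 2 to compound 3 (2.27 log units; beyond the scatter)). It shows that lengthening this chain alone, with the same end group, moves the number strongly upwards, a shift larger than the one seen on exchanging the group on the aromatic carbon, and it puts compound 3 above the amide-containing compound 1 (a 13-fold higher number from compound 1 to compound 3 (1.12 log units; beyond the scatter)). Nothing available accounts for the size of this step. The compounds shown leave open how the number runs at chain lengths between those of compound 2 and compound 3, and with a still longer chain. They also leave open whether the step depends on the selenium, which a sulfur atom in its place could test.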